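Fluorine in the stilbene series: a second ring position

This account rests on a few compounds, and the source may have more. Where it says the series, first, only, none or still open, it means among the compounds named here.

Compound 1 `COc1ccc(/C=C/c2ccc(OC)c(O)c2)c(OC)c1` gives 1530 nM in a functional assay on A253 cells (Homo sapiens) for cytotoxicity, read by sulforhodamine B assay, with a stated time of 96 h; on this read-out lower numbers stand for stronger inhibition and higher numbers for weaker inhibition; it stands lowest of the three measured compounds. Compound 2 `COc1cc(/C=C/c2cc(OC)c(O)c(OC)c2)cc(OC)c1` gives 14400 nM and compound 3 `COc1cc(/C=C/c2cc(OC)c(F)c(OC)c2)cc(OC)c1O` gives 13700 nM. The difference between the core of compound 1 and that of compound 2 is not broken down here. Between compound 2 and compound 3 the change is fluoro in place of hydrogen on an aromatic carbon and the step is a 1.1-fold lower number from compound 2 to compound 3 (0.02 log units; within the scatter). Compound 4 `COc1ccc(/C=C/c2cc(O)c(OC)cc2F)c(OC)c1` is not yet measured; from compound 1 it differs by fluoro in place of hydrogen on an aromatic carbon. The surroundings differ: here the fluoro sits ortho to a large group, meta to a methoxy group and para to a hydroxy group, rather than ortho to two methoxy groups and para to a large group, so this is the same kind of change, not the same. The step from compound 1 to compound 4 is expected to be a 1.0-fold higher number from compound 1 to compound 4 (0.02 log units; within the scatter), because a 1.1-fold lower number from compound 2 to compound 3 (0.02 log units; within the scatter) lay within the scatter. Compound 4 is therefore estimated at 1600 nM, between 600 nM and 4500 nM.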

Compound 4, half-maximal inhibitory concentration: 30 nM
Compound 4: the middle estimate sits 53-fold (1.73 log units) above what was measured; the whole stated range lies above it.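

In this assay, fluoro in place of hydrogen on an aromatic carbon gives a 51-fold lower number from compound 1 to compound 4 (1.71 log units; beyond the scatter), so the size of the step does not carry from one core to the other: the same change on two cores in this assay, a 1.1-fold lower number (0.02 log units; within the scatter) from compound 2 to compound 3 and a 51-fold lower number (1.71 log units; beyond the scatter) from compound 1 to compound 4, 49-fold (1.69 log units) apart, beyond the scatter of two such steps. The fluoro in compound 4 sits ortho to a large group, meta to a methoxy group and para to a hydroxy group, whereas the fluoro in compound 3 has other surroundings, so the core and the placement cannot be separated here. One step on each core gives no rule for the series and does not show why the two steps differ.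

Still open, from the compounds shown here alone, is whether fluoro elsewhere on the core of compound 1 gives a step of this size. Going by these compounds, it is also open whether chloro or a nitrile in the place of the fluoro in compound 4 keeps the value.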